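Cytotoxicity of chalcone amides on Vero cells

The compounds below may be only part of what the source reports. "The series", "measured", "known", "first", "only" and "open" are said of these compounds alone.

Compound 1 `COC(=O)c1cc(-c2cccc(NC(=O)c3ccc(/C=C/C(=O)c4ccccc4)cc3)c2)on1` gives > 50 ug/mL in an ADME assay on Vero cells (Chlorocebus sabaeus) for cytotoxicity, read by MTT assay, with a stated time of 72 h (on this read-out higher numbers stand for lower toxicity in this test and lower numbers for higher toxicity in this test), which is a limit of the assay.
Compound 2 `COC(=O)c1cc(-c2cccc(NC(=O)c3ccc(/C=C/C(=O)c4cccc([N+](=O)[O-])c4)cc3)c2)on1` gives > 40 ug/mL in this assay, also a limit.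
Compound 3 `COC(=O)c1cc(-c2cccc(NC(=O)c3ccc(/C=C/C(=O)c4ccccc4C)cc3)c2)on1` gives > 25 ug/mL in this assay, again a limit.

Compound 3 therefore sits at the limit of > 25 ug/mL in this assay, at which 1 of the 3 values shown sits, and the other two values are limits as well. The steps a step that the two limits leave unreadable from compound 1 to compound 3 and a step that the two limits leave unreadable from compound 2 to compound 3 bear on the next change but give no readable size. Compound 4 `COC(=O)c1cc(-c2cccc(NC(=O)c3ccc(/C=C/C(=O)c4ccc(OC)c(OC)c4)cc3)c2)on1` differs by 3,4-dimethoxyphenyl in place of 2-methylphenyl on a carbonyl carbon. With three limits and no readable step, no movement beyond the scatter is expected. Compound 4 is estimated at 50 ug/mL, from 20 ug/mL to 120 ug/mL, which would be the expected step that the limit leaves unreadable from compound 3 to compound 4.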

Compound 4, half-maximal cytotoxic concentration: > 50 ug/mL
Compound 4 ended at the assay's limit; the forecaster's own chance of this, stated with the estimate: 80%; the middle value lies on the limit itself.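

Within the data shown here, compound 4, like compound 1, compound 2 and compound 3, gives only a limit, so no step to compound 4 can be read. The compounds shown leave open whether exchanging the group on the carbonyl carbon changes cytotoxicity at all.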